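The source may hold more compounds than are shown below. What is called first, only, known or untested is meant among the compounds shown, and "the series" means these compounds.

Of the compounds shown here, two of a shared core have been measured. Compound 1 `N=C(N)c1ccc(-c2ccc(-c3cc(Cl)cc(Cl)c3)s2)cc1` carries two chloro groups on its outer ring; in a functional assay on SN12C cells (Homo sapiens) for inhibition, read by sulforhodamine B assay, with a stated time of 48 h (a lower number here means a stronger inhibitor of growth, a higher number a weaker inhibitor of growth), compound 1 gives 1570 nM. Compound 2 `N=C(N)c1ccc(-c2ccc(-c3ccc(Cl)cc3)s2)cc1F` carries one chloro group on that outer ring and a fluoro group beside the amidine-bearing ring; in this assay compound 2 gives 517 nM. Of these two numbers, that of compound 2 is the lower, and the number of compound 1 stands higher by a margin beyond the usual scatter, so compound 2 is the stronger inhibitor of growth among the two.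

The next compound, compound 3 `N=C(N)c1ccc(-c2ccc(-c3ccccc3)s2)cc1F`, differs from compound 2 in one place: hydrogen in place of chloro on an aromatic carbon. Among the measured compounds shown here, no measured pair in this set shows what removing a chloro group does here, so the expectation rests on the change alone. A modest weakening is expected, a step of a 2.3-fold higher number from compound 2 to compound 3 (0.37 log units; beyond the scatter) in this assay. Compound 3 is thus estimated at 1200 nM, within a range from 500 nM to 3000 nM.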

Compound 3, concentration for 50% growth inhibition: 8010 nM
Compound 3: the middle estimate sits 6.7-fold (0.82 log units) below what was measured, and the stated range ends below it.
By their numbers in this assay, from the lowest: compound 2; then compound 1; then compound 3.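

Replacing a single chloro group with hydrogen on the outer ring has a large effect: in this assay, the change gives a 15-fold higher number from compound 2 to compound 3 (1.19 log units; beyond the scatter). Among the compounds shown here, this is the first pair here that differs in only one place, and it shows that the 4-chlorophenyl group of compound 2 counts for much of its growth inhibition, while the plain phenyl group of compound 3 retains far less. No measurement here explains why one atom at this position matters so much.

Going by these compounds, it remains open whether this strength is specific to chloro or whether other groups at this position would serve as well. A bromo, methyl or methoxy group on the same aromatic carbon, para to a large group, could help separate those two possibilities.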